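Working notes on the series, compound 4 pending

The compounds below may be only part of what the source reports. "The series", "measured", "known", "first", "only" and "open" are said of these compounds alone.

In an assay on isolated protein for binding affinity to corticotropin-releasing factor receptor 1 (Homo sapiens) (on this read-out higher numbers stand for weaker inhibition and lower numbers for stronger inhibition), compound 1 `CC(=O)/C(=N\c1cccc(C)c1)NNc1ccccc1C` gives 526 nM. Compound 3 `C#Cc1cccc(/N=C(/NNc2ccccc2C)C(C)=O)c1` gives 62 nM, the step of an 8.5-fold lower number from compound 1 to compound 3 (0.93 log units; beyond the scatter). Compound 2 `CC(=O)/C(=N\c1cccc(C#N)c1)NNc1ccccc1C` gives only a limit, > 10000 nM, and not a number. Compound 2 thus stands at the limit of > 10000 nM in this assay, at which 1 of the 3 values shown sits, so the steps of an at least 19-fold higher number from compound 1 to compound 2 (1.27 log units; beyond the scatter) and an at least 160-fold lower number from compound 2 to compound 3 (2.20 log units; beyond the scatter) are bounds rather than exact sizes.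

Compound 4 `CC(=O)/C(=N\c1cccc(C#N)c1)NNc1ccccc1C(F)(F)F` differs from compound 2 by trifluoromethyl in place of methyl on an aromatic carbon. None of the three measured steps touches this aromatic carbon; all of them exchange the methyl, cyano or ethynyl group on the other ring, so they give no direction for the present change. What bears on compound 4 is only the limit shown by compound 2. Compound 4 is therefore expected to remain at or beyond that limit, a step that the limit leaves unreadable from compound 2 to compound 4. For compound 4 the estimate is 15000 nM, in a range from 3000 nM to 60000 nM, and it is expected that this assay again reports only a limit.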

Compound 4, inhibition constant: > 10000 nM
Compound 4: only a limit was reported; the forecaster's own chance of this, stated with the estimate: 75%; the middle value does not contradict the limit.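

In this assay, within the data shown here, compound 4 gives > 10000 nM as a limit and not a number, and compound 2 also stands at a limit, so no step between compound 2 and compound 4 can be read. The compounds shown leave open how trifluoromethyl in place of methyl on an aromatic carbon acts where the read-out gives a number rather than a limit.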